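Ester in place of amine on the aryl amide of compound 2

The compounds below may be only part of what the source reports. "The series", "measured", "known", "first", "only" and "open" are said of these compounds alone.

Of the compounds shown here, three have been measured in an assay on L cells for inhibition of Protein-serine O-palmitoleoyltransferase porcupine (Mus musculus), read by reporter gene assay, with a stated time of 24 h; on this read-out higher numbers stand for an effect only at larger amounts of compound and lower numbers for an effect already at smaller amounts. Compound 1 `O=C(CNC(=O)c1nn(-c2ccccc2)c(=O)c2ccccc12)Nc1nccs1` gives > 25000 nM in this assay, which is a limit of the assay and not a number (the limit of > 25000 nM in this assay, at which 1 of the 3 values shown sits). Compound 2 `CN(C)c1ccc(NC(=O)CSc2nc3c(c(=O)n2-c2ccccc2)SCC3)cc1` gives > 1000 nM in this assay, again only a limit (the limit of > 1000 nM in this assay, at which 1 of the 3 values shown sits). Within the data shown here, compound 3 `COc1ccc(-n2c(SCC(=O)Nc3nc4ccc(C(F)(F)F)cc4s3)nc3c(c2=O)SCC3)cc1` gives 100 nM in this assay, the only measured number in the set. Compound 2 therefore stands at a limit: no effect was seen within the tested range, and no number can be placed against it. Among the measured compounds shown here, no two measured compounds differ in a single place, so no measured step is available to calibrate the change examined here.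

Compound 4 `CCOC(=O)c1ccc(NC(=O)CSc2nc3c(c(=O)n2-c2ccccc2)SCC3)cc1` differs from compound 2 in one place: ethoxycarbonyl in place of dimethylamino on an aromatic carbon. For the measured compounds named here, with compound 2 at a limit and no step of this kind measured, the size and direction of the change are open. The estimate reads as a move from the limit to a measured number, a step that the limit leaves unreadable from compound 2 to compound 4 in this assay, though a limit-only result remains a real possibility. Compound 4 is expected at 2000 nM in this assay, within a range of 300 nM to 15000 nM.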

Compound 4, half-maximal effective concentration: 300 nM
Compound 4: the middle estimate sits 6.7-fold (0.82 log units) above what was measured, and the stated range covers the measured number.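

Read in this assay, ethoxycarbonyl in place of dimethylamino on an aromatic carbon, para to a large group, gives an at least 3.3-fold lower number from compound 2 to compound 4 (0.52 log units; beyond the scatter). This is the only single-place step among the compounds shown, so it is the first direct sign that the group at this place on the aryl amide can move the read-out while the rest of the structure stays fixed. Compound 2 gives > 1000 nM in this assay, which is a limit of the assay, and the step is therefore only a lower bound on the true change, because its starting point carries no number: the limit of > 1000 nM in this assay, at which 1 of the 4 values shown sits.

From the compounds shown here alone, it remains open whether the ethyl ester itself is needed or whether losing dimethylamino is enough, a question that a carboxylic acid, a primary amide, a methyl ester or plain hydrogen at this place would help to settle. Going by these compounds, it also remains open how a longer alkyl ester or a nitrile would sit relative to compound 4, and whether the same exchange would give a step of similar size on another core.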